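The source may report more compounds than this note shows. Statements on the series, on what has been measured and on what is new or still open speak of the compounds shown alone.

Two compounds share one core and differ only in how a single saturated chain carbon is drawn. Compound 1 `Cc1ccc(NC(=O)c2ccc(C)c(C(F)(F)F)c2)cc1C#Cc1nn(C[C@@H](C)CO)c2ncnc(N)c12` and compound 2 `Cc1ccc(NC(=O)c2ccc(C)c(C(F)(F)F)c2)cc1C#Cc1nn(C[C@H](C)CO)c2ncnc(N)c12` were both tested in a functional assay on MDA-MB-435 cells (Homo sapiens) for antiproliferative activity, read by MTT assay, with a stated time of 72 h (on this read-out lower numbers stand for stronger inhibition and higher numbers for weaker inhibition), where compound 1 gives 123 nM and compound 2 gives 61 nM. That is a 2.0-fold lower number from compound 1 to compound 2 (0.30 log units; within the scatter), so the two numbers cannot be told apart with confidence; compound 2 simply has the lower of the two numbers, with compound 1 the nearest neighbour. Compound 3 `Cc1ccc(NC(=O)c2ccc(Cl)c(C(F)(F)F)c2)cc1C#Cc1nn(C[C@H](C)CO)c2ncnc(N)c12` keeps the configuration of compound 2 and changes (chloro in place of methyl on an aromatic carbon), chloro in place of methyl on an aromatic carbon. Among the measured compounds shown here, no measured step touches the 4-methyl-3-(trifluoromethyl)phenyl group; the only measured step, the one of configuration, stayed within the scatter. A step of a 1.0-fold lower number from compound 2 to compound 3 (0.01 log units; within the scatter) is therefore expected, with no change beyond the scatter. Compound 3 is estimated at 60 nM, between 25 nM and 150 nM.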

Compound 3, half-maximal inhibitory concentration: 323 nM
Compound 3: the middle estimate sits 5.4-fold (0.73 log units) below what was measured; measured number outside the range, above it.
By their numbers in this assay, from the lowest: compounds 2 and 1 (each within the scatter of the next); then compound 3.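

Methyl at this aromatic carbon, ortho to a trifluoromethyl group, turns out to matter in this assay: exchanging it for chloro gives a 5.3-fold higher number from compound 2 to compound 3 (0.72 log units; beyond the scatter). Among the compounds shown here, this is the only step here that lies beyond the scatter, whereas the change of configuration on the saturated chain, a 2.0-fold lower number from compound 1 to compound 2 (0.30 log units; within the scatter), does not, so the aromatic group is a more telling place to alter than that chain carbon in these compounds. Methyl and chloro each count as one heavy atom with no hydrogen-bond donors or acceptors, and nothing at hand explains why the number moves.

As far as these compounds go, what fluoro, methoxy or an amine would do at this carbon stays open. Also open, from the compounds shown here alone, is whether the same exchange would give a similar step in the configuration of compound 1.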